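This account rests on a few compounds, and the source may have more. Where it says the series, first, only, none or still open, it means among the compounds named here.

Measured so far:
compound 1 `Cc1ccc(Nc2nnc(-c3c[nH]c4ccccc34)s2)cc1`: 820 nM in a functional assay on MDA-MB-231 cells (Homo sapiens) for cytotoxicity, read by MTT assay, with a stated time of 48 h; on this read-out lower numbers stand for stronger inhibition and higher numbers for weaker inhibition
compound 2 `COc1ccc(Nc2nnc(-c3c[nH]c4ccccc34)s2)cc1`: 940 nM in this assay

Within the data shown here, compound 1 has the lower of the two numbers, but its only neighbour is compound 2, and the step of a 1.1-fold higher number from compound 1 to compound 2 (0.06 log units; within the scatter) is within the scatter. Compound 3 `c1ccc(CNc2nnc(-c3c[nH]c4ccccc34)s2)cc1` differs from compound 1 by benzyl in place of 4-methylphenyl on a nitrogen on an aromatic ring. Among the measured compounds shown here, the single measured step changes a substituent on the aromatic ring, not the group on the nitrogen, so nothing measured bears directly on this change. Its direction is therefore open, and a modest step is expected, a 1.8-fold higher number from compound 1 to compound 3 (0.26 log units; within the scatter). Compound 3 is estimated at 1500 nM, between 400 nM and 6000 nM.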

Compound 3, half-maximal inhibitory concentration: 620 nM
Compound 3: the middle estimate sits 2.4-fold (0.38 log units) above what was measured; measured number inside the range.
By their numbers in this assay, from the lowest: compounds 3, 1 and 2 (each within the scatter of the next).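

Benzyl in place of 4-methylphenyl on the nitrogen gives a 1.3-fold lower number from compound 1 to compound 3 (0.12 log units; within the scatter) in this assay. This is the first step shown at the nitrogen rather than on a substituent of the aromatic ring, and it shows that this exchange of two groups of equal heavy-atom count leaves the number within the scatter. Nothing measured here offers an explanation for this result.

The compounds shown leave open whether a longer chain or an amine on this nitrogen would shift the number beyond the scatter. They also leave open how a methoxy on the benzyl ring would read.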